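Compound 3 to compound 4: exchanging one aryl group

This account rests on a few compounds, and the source may have more. Where it says the series, first, only, none or still open, it means among the compounds named here.

In a functional assay on A549 cells (Homo sapiens) for antiproliferative activity, read by MTT assay, with a stated time of 72 h (on this read-out lower numbers stand for stronger inhibition and higher numbers for weaker inhibition), compound 1 (`COc1ccccc1-c1ccc2ncn(-c3cc(OC)c(OC)c(OC)c3)c2c1`) gives 4320 nM, compound 2 (`COc1ccc(-c2ccc3ncn(-c4cc(OC)c(OC)c(OC)c4)c3c2)cc1O`) gives 200 nM and compound 3 (`COc1cc(-n2cnc3ccc(-c4ccc(C(F)(F)F)cc4)cc32)cc(OC)c1OC`) gives 3390 nM. Compound 3 is therefore the middle number of the set, but the measured values show a 1.3-fold lower number from compound 1 to compound 3 (0.11 log units; within the scatter), while the gap to the lowest number is a 17-fold higher number from compound 2 to compound 3 (1.23 log units; beyond the scatter).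

Compound 4 (`COc1cc(-n2cnc3ccc(-c4cccc(Cl)c4)cc32)cc(OC)c1OC`) has 3-chlorophenyl in place of 4-(trifluoromethyl)phenyl on an aromatic carbon. For the measured compounds named here, no measured step covers 3-chlorophenyl directly. The large steps, a 22-fold lower number from compound 1 to compound 2 (1.33 log units; beyond the scatter) and a 17-fold higher number from compound 2 to compound 3 (1.23 log units; beyond the scatter), both involve the 3-hydroxy-4-methoxyphenyl group of compound 2, which neither compound 3 nor compound 4 carries. Going by the values given here, the closest precedent is the exchange without that group, a 1.3-fold lower number from compound 1 to compound 3 (0.11 log units; within the scatter), so no change beyond the scatter is expected in this assay. The estimate amounts to a 1.2-fold lower number from compound 3 to compound 4 (0.08 log units; within the scatter). Compound 4 is expected at 2800 nM, with an estimated range of 900 nM to 8000 nM.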

Compound 4, half-maximal inhibitory concentration: 7050 nM
For compound 4 the middle estimate is 2.5-fold (0.40 log units) below the measured one; the range from low to high includes it.
By their numbers in this assay, from the lowest: compound 2; then compounds 3, 1 and 4 (each within the scatter of the next, the first and the last beyond it).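

In this assay, this position now shows a step beyond the scatter between two aryl groups other than 3-hydroxy-4-methoxyphenyl (a 2.1-fold higher number from compound 3 to compound 4 (0.32 log units; beyond the scatter)), though it is modest, while the exchange for 2-methoxyphenyl stays within the scatter (a 1.6-fold higher number from compound 1 to compound 4 (0.21 log units; within the scatter)). The gap to 3-hydroxy-4-methoxyphenyl is also the widest seen so far (a 35-fold higher number from compound 2 to compound 4 (1.55 log units; beyond the scatter)), so compound 2 stands apart from all three other compounds. No measurement on these compounds explains these differences.

Going by these compounds, the exchange from compound 3 to compound 4 changes both the substituent and its place on the ring, so the contribution of each remains open. Also open, on these data alone, is whether compound 2 needs both its hydroxy and its methoxy group, and how an amine or a carboxylic acid on this aryl ring would read.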